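Quaternary ammonium variants of a piperazine amide series

A few compounds are considered here, and "the series" means these few. Any claim that something is new, unique, unknown or untested is made for them only; others in the source may bear on it.

Measured so far:
Compound 1 `Cc1cc(C)c2cccc(OCc3c(Cl)ccc(S(=O)(=O)NC4(C(=O)N5CCN(C(=O)[C@H](CCCCN(C)C)N(C)C)CC5)CCCC4)c3Cl)c2n1` gives in an assay on isolated protein for binding affinity to B1 bradykinin receptor (Homo sapiens) (on this read-out higher numbers stand for weaker inhibition and lower numbers for stronger inhibition), only a limit, < 10000 nM.
Compound 2 `Cc1cc(C)c2cccc(OCc3c(Cl)ccc(S(=O)(=O)NC4(C(=O)N5CCN(C(=O)[C@@H](N)CCCC[N+](C)(C)C)CC5)CCCC4)c3Cl)c2n1` gives in this assay only a limit, < 10000 nM.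
Compound 3 `Cc1cc(C)c2cccc(OCc3c(Cl)ccc(S(=O)(=O)NC4(C(=O)N5CCN(C(=O)CCCCC[N+](C)(C)C)CC5)CCCC4)c3Cl)c2n1` gives in this assay only a limit, < 10000 nM.

Compound 3 therefore stands at the same limit as the other two measured compounds; no number is known for any of them, and the limit of < 10000 nM in this assay, at which 3 of the 3 values shown sit, covers all three values. The steps between them are accordingly unreadable: a step that the two limits leave unreadable from compound 1 to compound 2, a step that the two limits leave unreadable from compound 1 to compound 3 and a step that the two limits leave unreadable from compound 2 to compound 3.

Compound 4 `Cc1cc(C)c2cccc(OCc3c(Cl)ccc(S(=O)(=O)NC4(C(=O)N5CCN(C(=O)[C@H](CCCC[N+](C)(C)C)[N+](C)(C)C)CC5)CCCC4)c3Cl)c2n1` differs from compound 3 by a group of 4 heavy atoms (3 carbon, 1 nitrogen; no ring) in place of a hydrogen atom, on a saturated chain carbon bound to a carbonyl carbon and a saturated chain carbon. Among the measured compounds shown here, the closest measured step is the one from compound 2 to compound 3, hydrogen in place of amino at the same carbon, but it too is unreadable. For the measured compounds named here, no measured step gives a size or a direction for this change, so nothing beyond the scatter can be expected with any confidence, and the most likely outcome is that compound 4 also returns a limit. Compound 4 is estimated at 3000 nM, within 100 nM to 10000 nM, an expected step that the limit leaves unreadable from compound 3 to compound 4.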

Compound 4, inhibition constant: < 10000 nM
Compound 4 ended at the assay's limit (the forecaster's own chance of this, stated with the estimate: 80%); the middle value lies beyond the limit too.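

In this assay, among the compounds shown here, compound 4 gives only a limit, < 10000 nM, so no step from compound 2 or compound 3 to compound 4 can be read. The compounds shown leave open how far any of them differs in affinity, with one limit covering them all: the limit of < 10000 nM in this assay, at which 4 of the 4 values shown sit.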